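This account rests on a few compounds, and the source may have more. Where it says the series, first, only, none or still open, it means among the compounds named here.

Working notes on the series.

Within the data shown here, compound 1 `COc1ccc(-c2nc(CNC(=O)c3cccnc3)sc2-c2ccc(OC)cc2)cc1` is the one measured number in this set. In a functional assay (aorta) with Rattus norvegicus as the target (on this read-out lower numbers stand for an effect already at smaller amounts and higher numbers for an effect only at larger amounts of compound), compound 1 gives 8.2 uM. Compound 2 `CCOC(=O)C1=C(C)N=C(C)/C(=C(/O)OCC)C1c1nc(-c2ccc(OC)cc2)c(-c2ccc(OC)cc2)s1` returns only a limit of the assay in this assay, > 32 uM, so no number stands for it. Thus compound 1 holds the only numerical value shown, while the other value sits at the limit of > 32 uM in this assay, at which 1 of the 2 values shown sits; nothing more can be said of the two together.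

Compound 3 `CCOC(=O)/C=C/c1nc(-c2ccc(OC)cc2)c(-c2ccc(OC)cc2)s1` is not yet measured. It differs from compound 1 by 2-(ethoxycarbonyl)ethenyl in place of (((pyridin-3-yl)carbonyl)amino)methyl on an aromatic carbon. Among the measured compounds shown here, no pair of measured compounds differing in one place is available, so no measured step guides this change. Still, the expectation is that the step in this assay from compound 1 to compound 3 goes toward larger amounts, beyond the scatter, as a 2.4-fold higher number from compound 1 to compound 3 (0.39 log units; beyond the scatter), because the other compound carrying an ester on the shared core, compound 2, sits at the limit of > 32 uM in this assay, at which 1 of the 2 values shown sits. On that basis compound 3 is expected to give about 20 uM in this assay, within a range of 6 uM to 60 uM, with a fair chance that only a limit is reported.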

Compound 3, concentration for half-maximal effect: > 100 uM
Compound 3 was reported as a limit (the forecaster's own chance of this, stated with the estimate: 35%); middle value at least 5.0-fold (0.69 log units) away from the limit.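

Among these compounds, at the aromatic carbon of the five-membered ring, next to the ring nitrogen and the ring sulfur, the group matters in this assay: 2-(ethoxycarbonyl)ethenyl in place of (((pyridin-3-yl)carbonyl)amino)methyl gives an at least 12-fold higher number from compound 1 to compound 3 (1.08 log units; beyond the scatter), a large step beyond the scatter and the first measured step. As far as these compounds go, compound 3 reaches only a limit of the assay, > 100 uM, which is not a number, so the true size of the step remains unknown beyond what is printed. With an ester on the shared core as well, compound 2 also stands at a limit, > 32 uM, so in this assay neither ester-bearing compound gives a number.

The step removes the pyridine ring and the amide in one change, and the compounds shown cannot tell which part accounts for the difference. A plain aminomethyl group or a benzoyl amide at this position would separate those two parts, and a carboxylic acid in place of the ethyl ester would show whether the ester itself is tied to the limit.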